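Swapping Bromo for Chloro on a Fused Aromatic Ring

A few compounds are considered here, and "the series" means these few. Any claim that something is new, unique, unknown or untested is made for them only; others in the source may bear on it.

Compound 1 `COc1ccc(-n2n[o+]c([O-])c2-c2nn3cc(-c4cc5ccccc5oc4=O)nc3s2)cc1` and compound 2 `COc1ccc(-n2n[o+]c([O-])c2-c2nn3cc(-c4cc5cc(Br)ccc5oc4=O)nc3s2)cc1` share one core and differ at a single aromatic carbon of a six-membered carbon ring within a fused two-ring system. In a functional assay on HT-29 cells (Homo sapiens) for cytotoxicity, read by sulforhodamine B assay (on this read-out higher numbers stand for weaker inhibition of growth and lower numbers for stronger inhibition of growth), compound 1 gives 3.14 ug/mL, and compound 2 gives 3.04 ug/mL. The step of a 1.0-fold lower number from compound 1 to compound 2 (0.01 log units; within the scatter) shows that placing bromo on that carbon left the number essentially unchanged. Of the two measured values, that of compound 2 is numerically the smaller, but its gap to compound 1 lies within the scatter, so the two compounds are indistinguishable on this read-out.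

Compound 3 `COc1ccc(-n2n[o+]c([O-])c2-c2nn3cc(-c4cc5cc(Cl)ccc5oc4=O)nc3s2)cc1` carries the change (chloro in place of bromo on an aromatic carbon), on an aromatic carbon of a six-membered aromatic ring of carbon only, meta to a fused ring and para to a fused ring. Going by the values given here, no measured step exchanges one halogen for another. The step of a 1.0-fold lower number from compound 1 to compound 2 (0.01 log units; within the scatter), from hydrogen to bromo at the same carbon, is the nearest guide, so moving from bromo to chloro is expected to stay within the scatter as well, which a 1.0-fold lower number from compound 2 to compound 3 (0.01 log units; within the scatter) expresses. Compound 3 is estimated at 3 ug/mL in this assay, with a range from 1.5 ug/mL to 6 ug/mL.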

Compound 3, concentration for 50% growth inhibition: 3.68 ug/mL
The estimate for compound 3 lay 1.2-fold (0.09 log units) below the measured number, and the stated range covers the measured number.
By their numbers in this assay, from the lowest: compounds 2, 1 and 3 (each within the scatter of the next).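

Chloro now joins bromo as a second halogen measured at this aromatic carbon, and in this assay exchanging one for the other gives a 1.2-fold higher number from compound 2 to compound 3 (0.08 log units; within the scatter), so this swap leaves the number within the usual variation between repeat measurements. Chloro in place of hydrogen gives a 1.2-fold higher number from compound 1 to compound 3 (0.07 log units; within the scatter), which is also within the scatter, so the finding no longer rests on bromo alone: hydrogen, bromo and chloro on this carbon, meta to a fused ring and para to a fused ring, cannot be told apart on this read-out. No measurement at hand explains why the three numbers sit so close together.

The compounds shown cover only hydrogen and two halogens at this carbon, so it remains open whether an amine, a carboxylic acid or a longer chain there would move the number beyond the scatter. From the compounds shown here alone, it also remains open whether the same small differences would appear with these groups on the other carbons of this ring, or in other cell lines.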